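The source may report more compounds than this note shows. Statements on the series, on what has been measured and on what is new or still open speak of the compounds shown alone.

In a functional assay on PC-3 cells (Homo sapiens) for antiproliferative activity, read by MTT assay, with a stated time of 72 h (a higher number here means a weaker inhibitor, a lower number a stronger inhibitor), the measured compounds are:

- compound 1 `O=C(N/N=C/c1ccccc1)Nc1ccc(Oc2ccnc3[nH]ccc23)c(F)c1` gives 7940 nM
- compound 2 `O=C(N/N=C/c1cccc([N+](=O)[O-])c1)Nc1ccc(Oc2ccnc3[nH]ccc23)c(F)c1` gives 5140 nM
- compound 3 `O=C(N/N=C/c1ccccc1)Nc1ccc(Oc2ccnc3[nH]ccc23)cc1` gives 10200 nM

Compound 3, at 10200 nM, lies within the scatter of both other compounds, so the three do not separate. Compound 4 `O=C(N/N=C/c1ccc(F)cc1)Nc1ccc(Oc2ccnc3[nH]ccc23)cc1` differs from it by fluoro in place of hydrogen on an aromatic carbon. Among the measured compounds shown here, two measured steps bear on this. One is a 1.5-fold lower number from compound 1 to compound 2 (0.19 log units; within the scatter), with nitro in place of hydrogen on the same phenyl ring. The other is a 1.3-fold higher number from compound 1 to compound 3 (0.11 log units; within the scatter), with hydrogen in place of fluoro on a different ring. Neither leaves the scatter, so no step beyond it is expected in this assay. The expected change is a 1.1-fold lower number from compound 3 to compound 4 (0.05 log units; within the scatter). For compound 4 the estimated value is 9000 nM, with an expected range from 4500 nM to 18000 nM.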

Compound 4, half-maximal inhibitory concentration: 7490 nM
For compound 4 the middle estimate is 1.2-fold (0.08 log units) above the measured one; the measured number falls inside the stated range.
By their numbers in this assay, from the lowest: compounds 2, 4, 1 and 3 (each within the scatter of the next).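

In this assay the change from phenyl to 4-fluorophenyl gives a 1.4-fold lower number from compound 3 to compound 4 (0.13 log units; within the scatter) and stays within the scatter. This adds a reading for fluoro para to a large group on the ring that earlier carried only a nitro group, a change that also stayed within the scatter. A single fluorine atom at this place therefore does not separate compound 4 from compound 3.

From the compounds shown here alone, whether an amine, a methoxy group or a carboxylic acid at this place would give a step beyond the scatter stays open. Nothing shown bears on why this step is so small.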